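The source may report more compounds than this note shows. Statements on the series, on what has been measured and on what is new or still open speak of the compounds shown alone.

Compound 1 `CCOc1ccc(NC(=O)c2c(N)n[nH]c2Nc2ccccc2)cc1` is tested in a functional assay on CCRF-CEM cells (Homo sapiens) for cytotoxicity, read by resazurin assay, with a stated time of 48 h (on this read-out lower numbers stand for stronger inhibition and higher numbers for weaker inhibition), and gives 4470 nM. Two compounds built on a different core accompany it: compound 2 `C=CCNc1[nH]nc2nnn(-c3ccc(OCC)cc3)c(=O)c12` gives 4730 nM in this assay, and compound 3 `CCOc1ccc(-n2nnc3n[nH]c(Nc4ccccc4)c3c2=O)cc1` gives 5920 nM. Compound 1 thus has the lowest of the three numbers, yet both of the others sit within the scatter of it, so the three compounds are not separated by this read-out.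

Compound 4 `CCOc1ccc(NC(=O)c2c(N)n[nH]c2NC)cc1` is the unmeasured partner of compound 1, from which it differs in one place: methyl in place of phenyl on a nitrogen on an aromatic ring. Among the compounds with values here, the only measured step that touches the same kind of position is the one from compound 2 to compound 3, where a phenyl took the place of an allyl on a nitrogen on an aromatic ring and gave a 1.3-fold higher number from compound 2 to compound 3 (0.10 log units; within the scatter). That step runs on another core and in the opposite sense, exchanging a small group for a phenyl, but it shows that a swap at such a nitrogen left the number within the scatter. On this basis no step beyond the scatter is expected for compound 4, though a slight rise is allowed for, and compound 4 is estimated at 6000 nM in this assay, with a range from 2500 nM to 15000 nM. The step from compound 1 that this estimate means is a 1.3-fold higher number from compound 1 to compound 4 (0.13 log units; within the scatter).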

Compound 4, half-maximal inhibitory concentration: 7900 nM
Compound 4: middle estimate off by 1.3-fold (0.12 log units), on the low side; measured number inside the range.
By their numbers in this assay, from the lowest: compounds 1, 2, 3 and 4 (each within the scatter of the next).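

On the core of compound 1, methylamino in place of anilino gives a 1.8-fold higher number from compound 1 to compound 4 (0.25 log units; within the scatter) in this assay. The earlier compounds shown here offered only a swap at such a nitrogen on another core, between allyl and phenyl, whereas this step stands on the core of compound 1 itself and shows that the phenyl can give way to a single methyl without the number leaving the scatter, so on this read-out the phenyl at this nitrogen is not required for a number in this range. No measurement bears on why this step has the size it has.

The compounds shown leave open whether any group at this nitrogen can separate the numbers at all, since the four compounds, taken in order of their numbers, each lie within the scatter of the next. How a longer chain such as butyl, a benzyl group, or a chain ending in an amine or a carboxylic acid would read at this nitrogen on the core of compound 1 remains an open question.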